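The compounds below may be only part of what the source reports. "The series", "measured", "known", "first", "only" and "open" are said of these compounds alone.

Working notes on the series. Compound 1 `O=C1/C(=C\c2ccc(F)cc2)c2ccccc2N1c1c(Cl)cccc1Cl` gives 8 ug/mL in a functional assay on HuTu80 cells (Homo sapiens) for cytotoxicity, read by MTT assay, with a stated time of 72 h; on this read-out lower numbers stand for an effect already at smaller amounts and higher numbers for an effect only at larger amounts of compound. Going by the values given here, compound 2 `O=C1/C(=C\c2ccc(O)cc2)c2ccccc2N1c1c(Cl)cccc1Cl` gives 25 ug/mL in this assay, so the step of a 3.1-fold higher number from compound 1 to compound 2 (0.49 log units; beyond the scatter) is the one change in the set that moves the number beyond the scatter. Compound 3 `O=C1/C(=C\c2cccc(Br)c2)c2ccccc2N1c1c(Cl)cccc1Cl` gives 7 ug/mL in this assay. Among the compounds with values here, compound 3 carries the lowest number of the three, yet the step of a 1.1-fold lower number from compound 1 to compound 3 (0.06 log units; within the scatter) is within the scatter, so compounds 1 and 3 cannot be ordered against each other; only the step of a 3.6-fold lower number from compound 2 to compound 3 (0.55 log units; beyond the scatter) separates compound 3 clearly from another member.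

Compound 4 `O=C1/C(=C\c2ccccc2Cl)c2ccccc2N1c1c(Cl)cccc1Cl` differs from compound 3 in one place: 2-chlorophenyl in place of 3-bromophenyl on a double-bonded chain carbon bound to a double-bonded ring carbon. Within the data shown here, two measured steps bear on this change. The step of a 1.1-fold lower number from compound 1 to compound 3 (0.06 log units; within the scatter) shows that exchanging one halogen-bearing phenyl for another, with the halogen at a different position, left the number where it was. The step of a 3.6-fold lower number from compound 2 to compound 3 (0.55 log units; beyond the scatter) shows that only the hydroxy-bearing phenyl stood apart. On that basis, the swap of 3-bromophenyl for 2-chlorophenyl is expected to give no step beyond the scatter in this assay, an expected step of a 1.3-fold higher number from compound 3 to compound 4 (0.11 log units; within the scatter). Compound 4 is therefore estimated at 9 ug/mL in this assay, with an expected range from 4 ug/mL to 20 ug/mL.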

Compound 4, concentration for half-maximal effect: > 100 ug/mL
Compound 4 gave a limit, no number; the forecaster's own chance of this, stated with the estimate: 5%; middle value at least 11-fold (1.04 log units) away from the limit.
By their numbers in this assay, from the lowest: compounds 3 and 1 (each within the scatter of the next); then compound 2. At a limit, above all of these: compound 4.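

In this assay compound 4 stands at a limit, not a number: the limit of > 100 ug/mL in this assay, at which 1 of the 4 values shown sits.

Going by these compounds alone, the steps of an at least 14-fold higher number from compound 3 to compound 4 (1.15 log units; beyond the scatter) and an at least 12-fold higher number from compound 1 to compound 4 (1.09 log units; beyond the scatter) are large, and an at least 4.0-fold higher number from compound 2 to compound 4 (0.60 log units; beyond the scatter) shows that the 2-chlorophenyl group also separates from the 4-hydroxyphenyl group, which had been the only group apart from the others at this place. Halogen-bearing phenyl groups on this double-bonded chain carbon bound to a double-bonded ring carbon therefore do not behave as one class, and the computed counts do not separate 3-bromophenyl from 2-chlorophenyl, since both have the same number of heavy atoms, hydrogen-bond donors and hydrogen-bond acceptors and neither has a net charge.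

The compounds shown leave open whether the step follows the chlorine itself or the different placement of the halogen on the phenyl ring, and the limit leaves the true size of all three steps open. From the compounds shown here alone, how a phenyl ring carrying an amine, a carboxylic acid or a methoxy group would behave at this place also stays open.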